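The source may hold more compounds than are shown below. What is called first, only, known or untested is meant among the compounds shown, and "the series" means these compounds.

Among the measured compounds shown here, compound 1 `N#Cc1c(Cl)nc(SCc2nc3ccccc3[nH]2)nc1-c1ccccc1` gives 11.3 nM in a functional assay on K562 cells (Homo sapiens) for cytotoxicity, read by MTT assay, with a stated time of 3 days (on this read-out lower numbers stand for stronger inhibition and higher numbers for weaker inhibition), the lower of the two numbers so far, though compound 2 sits within the scatter of it. Compound 2 `CNc1nc(SCc2nc3ccccc3[nH]2)nc(-c2ccccc2)c1C#N` gives 13.2 nM in this assay, a step of a 1.2-fold higher number from compound 1 to compound 2 (0.07 log units; within the scatter). Compound 3 `N#Cc1c(NC(N)=O)nc(SCc2nc3ccccc3[nH]2)nc1-c1ccccc1` differs from compound 1 by ureido in place of chloro on an aromatic carbon. For the measured compounds named here, the only step bearing on this position, that from compound 1 to compound 2, stayed within the scatter, so no more than a small shift in this assay is expected here, if anything toward a higher number. Compound 3 is therefore estimated at 20 nM, between 8 nM and 60 nM, an expected step of a 1.8-fold higher number from compound 1 to compound 3 (0.25 log units; within the scatter).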

Compound 3, half-maximal inhibitory concentration: 4.54 nM
Estimate against measurement, compound 3: 4.4-fold (0.64 log units) above; the measured number lies below the stated range.
By their numbers in this assay, from the lowest: compound 3; then compounds 1 and 2 (each within the scatter of the next).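

At this position, on an aromatic carbon ortho to a cyano group, ureido in place of chloro gives a 2.5-fold lower number from compound 1 to compound 3 (0.40 log units; beyond the scatter) in this assay and so moves the number beyond the scatter, which methylamino did not do. Carbamoyl in place of methyl on the nitrogen gives a 2.9-fold lower number from compound 2 to compound 3 (0.46 log units; beyond the scatter) and so places the gain on the added carbamoyl, with ureido's 4 heavy atoms accommodated here. No measurement on hand explains this gain.

On these data alone, it remains open whether the gain needs the whole ureido group. An unsubstituted amine, an acetamido group and a methylureido group would each test a part of it.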